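The source may report more compounds than this note shows. Statements on the series, on what has been measured and on what is new or still open speak of the compounds shown alone.

Compound 1 `O=C(NC1CC1)N1CCN(c2cnccc2-c2ccccc2)CC1` gives 52 nM in an assay on HEK293F cells for inhibition of cholesterol 24-hydroxylase (Homo sapiens), read by trypan blue exclusion, with stated times of 15 min and 5 h; on this read-out higher numbers stand for weaker inhibition and lower numbers for stronger inhibition.
Compound 2 `O=C(NC1CC1)c1ccc(-c2cnccc2-c2ccccc2)cc1` gives 74 nM in this assay.
Compound 3 `O=C(NC1CC1)C1CCN(c2cncnc2-c2ccccc2)CC1` gives 44 nM in this assay.

Among these three numbers compound 3 has the lowest, yet its gaps to compound 1 and to compound 2 both lie within the usual scatter of repeated measurements, so no order among the three can be read from them. Compound 4 `CCN(C)C(=O)C1CCN(c2cncnc2-c2ccccc2)CC1` differs from compound 3 in one place: ethyl(methyl)amino in place of cyclopropylamino on a carbonyl carbon, that is, the cyclopropylcarbamoyl becomes an ethyl(methyl)carbamoyl. Among the compounds with values here, no measured pair shows this exchange, so there is no step to lean on. The expectation in this assay is a small shift toward weaker inhibition, of a size that may not rise beyond the scatter. For compound 4 the estimate is 100 nM, within 35 nM to 300 nM, which amounts to an expected step of a 2.3-fold higher number from compound 3 to compound 4 (0.36 log units; beyond the scatter).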

Compound 4, half-maximal inhibitory concentration: 14 nM
For compound 4 the middle estimate is 7.1-fold (0.85 log units) above the measured one; the measured number lies below the stated range.
By their numbers in this assay, from the lowest: compound 4; then compounds 3, 1 and 2 (each within the scatter of the next).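

Swapping cyclopropylamino for ethyl(methyl)amino on the carbonyl carbon gives a 3.1-fold lower number from compound 3 to compound 4 (0.50 log units; beyond the scatter) in this assay, the first step in this set to rise beyond the scatter. This position therefore responds to the group it carries, and inhibition grows stronger even though the three-membered ring and the amide hydrogen both leave. Nothing available here explains this gain. Because the ring and the amide hydrogen leave together, this single exchange cannot show which loss matters. From the compounds shown here alone, how dimethylamino, diethylamino or morpholine would read on the same carbonyl carbon remains open.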